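The source may hold more compounds than are shown below. What is called first, only, known or untested is meant among the compounds shown, and "the series" means these compounds.

Compound 2 `COc1cc(-c2nn(-c3cccc(NC(=O)c4ccc(Cl)c(C(F)(F)F)c4)c3)cc2-c2ccncc2)ccc1Cl` carries chloro in place of hydrogen on an aromatic carbon relative to compound 1 `COc1cc(-c2nn(-c3cccc(NC(=O)c4cccc(C(F)(F)F)c4)c3)cc2-c2ccncc2)ccc1Cl`. In a functional assay on TK-10 cells (Homo sapiens) for inhibition, read by sulforhodamine B assay, with a stated time of 48 h (a lower number here means a stronger inhibitor of growth, a higher number a weaker inhibitor of growth), compound 1 gives only a limit, > 50000 nM. In this assay compound 2 likewise gives only a limit, > 32500 nM. The step that the two limits leave unreadable from compound 1 to compound 2 is thus unreadable. Compound 3 `COc1cc(-c2nn(-c3cccc(NC(=O)Nc4ccc(Cl)c(C(F)(F)F)c4)c3)cc2-c2ccncc2)ccc1Cl` differs from compound 2 by (4-chloro-3-(trifluoromethyl)phenyl)amino in place of 4-chloro-3-(trifluoromethyl)phenyl on a carbonyl carbon. Going by the values given here, no measured step bears on this change, and both values shown sit at limits the limit of > 32500 nM in this assay, at which 1 of the 2 values shown sits (the limit of > 50000 nM in this assay, at which 1 of the 2 values shown sits), so no direction is readable. The step that the limit leaves unreadable from compound 2 to compound 3 is expected to be none beyond the scatter. Compound 3 is estimated at 40000 nM, range 15000 nM to 150000 nM, most likely again reported only as a limit.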

Compound 3, concentration for total growth inhibition: 13500 nM
Compound 3: middle estimate off by 3.0-fold (0.47 log units), on the high side, and the stated range ends above it.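

Putting (4-chloro-3-(trifluoromethyl)phenyl)amino on the carbonyl carbon gives the only compound shown in this assay whose value is a number and not a limit, with an at least 2.4-fold lower number from compound 2 to compound 3 (0.38 log units; beyond the scatter). The same change, with the chloro counted in, gives an at least 3.7-fold lower number from compound 1 to compound 3 (0.56 log units; beyond the scatter). Compound 2 stands only as a limit, so the true size of its step stays open: the limit of > 32500 nM in this assay, at which 1 of the 3 values shown sits.

Going by these compounds, whether the added nitrogen or its hydrogen carries the step remains open; methylamino or an oxygen in the same place on the carbonyl carbon would separate the two. The role of the chloro alongside this amino link is also unresolved.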